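A few compounds are considered here, and "the series" means these few. Any claim that something is new, unique, unknown or untested is made for them only; others in the source may bear on it.

Measured compounds:
- compound 1, `COc1nc(C)c(Nc2nc(Cl)cn([C@H](COC(=O)c3cccnc3)C3CC3)c2=O)cc1C`, 5.2 nM
- compound 2, `COc1nc(C)c(Nc2nc(Cl)cn([C@H](COC(=O)Nc3cc(Cl)cc(Cl)c3)C3CC3)c2=O)cc1C`, 1.7 nM

Both numbers come from an assay on frontal cortex for displacement of a labelled ligand from corticotropin-releasing factor receptor 1 (Rattus norvegicus), with a stated time of 2 h; a higher number here means a weaker inhibitor, a lower number a stronger inhibitor. Going by the values given here, compound 2 gives the lower of the two; the only step recorded, a 3.1-fold lower number from compound 1 to compound 2 (0.49 log units; beyond the scatter), sets it apart from compound 1 by a modest margin that lies beyond the scatter.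

Compound 3, `CCNC(=O)OC[C@H](C1CC1)n1cc(Cl)nc(Nc2cc(C)c(OC)nc2C)c1=O`, has not been measured in this assay. Set against compound 2 the difference is ethyl in place of 3,5-dichlorophenyl on an amide-type nitrogen. The carbamate itself is kept; only the group on its nitrogen changes, and the change is a shrinkage from an aromatic ring to a short chain.

Among the compounds with values here, no measured step covers this exchange directly. Within the data shown here, the one step available, from compound 1 to compound 2, concerns the other side of the carbonyl and ends in the dichlorophenyl carbamate, so it says nothing about what a smaller substituent on the carbamate nitrogen does. With so little to go on, compound 3 is expected to sit somewhat weaker than compound 2, a step of a 3.5-fold higher number from compound 2 to compound 3 (0.55 log units; beyond the scatter), with wide uncertainty. The estimate for compound 3 in this assay is 6 nM, within a range from 1.5 nM to 25 nM.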

Compound 3, half-maximal inhibitory concentration: 14 nM
Beside the measured number, compound 3's estimate is 2.3-fold (0.37 log units) below it, and the stated range covers the measured number.
By their numbers in this assay, from the lowest: compound 2; then compound 1; then compound 3.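

In this assay, the amide-type nitrogen of the carbamate is now shown to respond to its substituent: ethyl in place of 3,5-dichlorophenyl gives an 8.2-fold higher number from compound 2 to compound 3 (0.92 log units; beyond the scatter), a larger step than any seen before in the series. This shows that the carbamate linkage alone does not carry the low number of compound 2, since the result depends on what sits on that nitrogen. The comparison on the carbonyl carbon also changes, as ethylamino in place of pyridin-3-yl gives a 2.7-fold higher number from compound 1 to compound 3 (0.43 log units; beyond the scatter), so the two carbamates fall on opposite sides of compound 1, and compound 3 goes against any reading that a carbamate outperforms pyridin-3-yl at this carbonyl carbon.

The compounds shown do not separate the contribution of the aromatic ring from that of its two chlorine atoms, and an unsubstituted phenyl, a single chlorine on the phenyl ring, a cyclohexyl or a longer chain such as butyl on the same nitrogen would each address that question. Nothing measured alongside these values explains the size of these steps or the order of the three compounds.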